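Buffer half-life series: replacing the vinylsulfonyl group

The source may report more compounds than this note shows. Statements on the series, on what has been measured and on what is new or still open speak of the compounds shown alone.

Compound 1 `C=CS(=O)(=O)c1cc(C(F)(F)F)cc(C(F)(F)F)c1`: in an ADME assay for pharmacokinetics, read by LC-MS, in phosphate buffer, with a stated time of 72 h, at pH 7.4, tested at 250 uM (on this read-out higher numbers stand for a longer-lived compound and lower numbers for a shorter-lived compound), compound 1 gives < 0.017 h, a limit of the assay.
Compound 2 `FC(F)(F)c1cc(C2CO2)cc(C(F)(F)F)c1`: in this assay compound 2 gives > 50 h, also a limit.
Compound 3 `Fc1cc(C(F)(F)F)cc(C(F)(F)F)c1`: in this assay compound 3 gives > 50 h, also a limit.

Compound 1 stands at the limit of < 0.017 h in this assay, at which 1 of the 3 values shown sits, the short-lived end of the shown values; the other two sit at the limit of > 50 h in this assay, at which 2 of the 3 values shown sit. The two measured steps that remove the vinylsulfonyl group, an at least 2900-fold higher number from compound 1 to compound 2 (3.46 log units; beyond the scatter) and an at least 2900-fold higher number from compound 1 to compound 3 (3.46 log units; beyond the scatter), are both large and both run toward a longer-lived compound. The remaining step, a step that the two limits leave unreadable from compound 2 to compound 3, gives no readable size.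

Compound 4 `FC(F)(F)c1cc(S)cc(C(F)(F)F)c1` differs from compound 1 by sulfanyl in place of vinylsulfonyl on an aromatic carbon. Both measured steps that remove the vinylsulfonyl group bear on this change, and both were large in the same direction. A large rise in this assay is therefore expected, an at least 1700-fold higher number from compound 1 to compound 4 (3.24 log units; beyond the scatter). How far the sulfanyl group carries compound 4 toward the long-lived limit is not told by the shown steps, so the expected value is set below that limit with a wide range. For compound 4 the estimate in this assay is 30 h, with a range from 6 h to 100 h.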

Compound 4, half-life: 33 h
Compound 4: middle estimate off by 1.1-fold (0.04 log units), on the low side; measured number inside the range.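

Among the compounds shown here, with sulfanyl on this aromatic carbon, compound 4 gives 33 h in this assay, the only value shown that is a number and not a limit, so this position can hold a group whose half-life is readable. Sulfanyl joins fluoro and oxiran-2-yl as a replacement for vinylsulfonyl with a large rise, an at least 1900-fold higher number from compound 1 to compound 4 (3.28 log units; beyond the scatter), which shows that sulfur on this carbon is compatible with a long half-life. Against the other two replacements only floors can be read, an at least 1.5-fold lower number from compound 3 to compound 4 (0.18 log units; that floor lies within the scatter) and an at least 1.5-fold lower number from compound 2 to compound 4 (0.18 log units; that floor lies within the scatter), so no order among the three can be stated.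

As far as these compounds go, it remains open whether the short half-life of compound 1 goes with the sulfonyl part or the vinyl end, and an ethylsulfonyl group at this place would separate the two. From the compounds shown here alone, how a methylthio group would compare with sulfanyl also remains open.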